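Trifluoromethyl Swap in a Series Resting at the Limit

The source may report more compounds than this note shows. Statements on the series, on what has been measured and on what is new or still open speak of the compounds shown alone.

Measured compounds:
compound 1, `CCCCC(Sc1ccc(OCCCOc2ccc(C)cc2)cc1)C(=O)O`: > 10000 nM
compound 2, `CCCCC(Sc1ccc(OCCCOc2ccc(Cl)cc2OC)cc1)C(=O)O`: > 10000 nM
compound 3, `Cc1cccc(OCCCOc2ccc(CCC(=O)O)cc2)c1C`: > 10000 nM

Each of these values is a limit of an assay for inhibition of Polyunsaturated fatty acid 5-lipoxygenase (Homo sapiens), read by HPLC, with a stated time of 10 min (on this read-out higher numbers stand for weaker inhibition and lower numbers for stronger inhibition), and not a number. Compound 1 itself stands only at that limit, as the limit of > 10000 nM in this assay, at which 3 of the 3 values shown sit, shows. Compound 4, `CCCCC(Sc1ccc(OCCCOc2cccc(C(F)(F)F)c2)cc1)C(=O)O`, is yet to be measured in this assay. The change from compound 1 is 3-(trifluoromethyl)phenyl in place of 4-methylphenyl on an oxygen on a saturated carbon. Going by the values given here, the one measured step at the same oxygen, a step that the two limits leave unreadable from compound 1 to compound 2, is unreadable because both ends rest at the limit of > 10000 nM in this assay, at which 3 of the 3 values shown sit. Among the compounds with values here, no measured step therefore bears on the change, and compound 4 is expected to remain at the limit as well, with an estimated step that the limit leaves unreadable from compound 1 to compound 4. Compound 4 is thus estimated at 15000 nM, within 4000 nM to 60000 nM.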

Compound 4, half-maximal inhibitory concentration: 9800 nM
For compound 4 the middle estimate is 1.5-fold (0.18 log units) above the measured one; the range from low to high includes it.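

In this assay compound 4 gives 9800 nM, the only number rather than a limit among the compounds shown for this position, on an oxygen on a saturated carbon. With 3-(trifluoromethyl)phenyl at this position the series thus comes into readable range, and the change is an at least 1.0-fold lower number from compound 1 to compound 4 (0.00 log units; that floor lies within the scatter), and an at least 1.0-fold lower number from compound 2 to compound 4 (0.00 log units; that floor lies within the scatter). Both steps start from a limit, so their true size stays unknown and these floors alone do not establish a gain: the limit of > 10000 nM in this assay, at which 3 of the 4 values shown sit.

As far as these compounds go, whether a nitrile in place of the trifluoromethyl group, or a longer chain at the same oxygen, would give a lower number remains open.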